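The source may hold more compounds than are shown below. What is called first, only, known or untested is meant among the compounds shown, and "the series" means these compounds.

Compound 1 `CNc1nc(SCc2nc3ccccc3[nH]2)nc(-c2ccccc2)c1C#N` is tested in a functional assay on HL-60 cells (Homo sapiens) for cytotoxicity, read by MTT assay, with a stated time of 3 days (a lower number here means a stronger inhibitor, a higher number a weaker inhibitor), where compound 1 gives 6.57 nM, the highest of the three numbers shown. Compound 2 `CCNc1nc(SCc2nc3ccccc3[nH]2)nc(-c2ccccc2)c1C#N` gives 3.96 nM and compound 3 `N#Cc1c(NC(N)=O)nc(SCc2nc3ccccc3[nH]2)nc1-c1ccccc1` gives 2.9 nM. Compound 4 `N#Cc1c(-c2ccccc2)nc(SCc2nc3ccccc3[nH]2)nc1N1CCNCC1` carries the change (piperazin-1-yl in place of methylamino on an aromatic carbon), so the group on that aromatic carbon is varied once more. Going by the values given here, the steps that bear on it alter the same group: a 1.7-fold lower number from compound 1 to compound 2 (0.22 log units; within the scatter) and a 2.3-fold lower number from compound 1 to compound 3 (0.36 log units; beyond the scatter). Neither step is large, and the two larger groups differ from each other by a 1.4-fold lower number from compound 2 to compound 3 (0.14 log units; within the scatter). A similarly small shift is therefore expected, either modest or none beyond the scatter. For compound 4 the expected value is 5 nM, between 2 nM and 13 nM. That estimate for compound 4 amounts to a 1.3-fold lower number from compound 1 to compound 4 (0.12 log units; within the scatter).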

Compound 4, half-maximal inhibitory concentration: 4 nM
The estimate for compound 4 lay 1.3-fold (0.10 log units) above the measured number; measured number inside the range.
By their numbers in this assay, from the lowest: compounds 3, 2, 4 and 1 (each within the scatter of the next, the first and the last beyond it).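

In this assay, a ring can take this position: piperazin-1-yl, with 6 heavy atoms in a six-membered non-aromatic ring, replaces methylamino, with 2 heavy atoms and no ring, giving a 1.6-fold lower number from compound 1 to compound 4 (0.22 log units; within the scatter). Against the other two groups, the result is a 1.0-fold higher number from compound 2 to compound 4 (0.00 log units; within the scatter) and a 1.4-fold higher number from compound 3 to compound 4 (0.14 log units; within the scatter), so every step to compound 4 stays within the scatter. Nothing measured here gives a reason for this. Still open, going by these compounds, is whether a carboxylic acid, a longer alkyl chain or a morpholine ring on this aromatic carbon would give a step beyond the scatter.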